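Hydrogen for Cyano: Expected Effect on Cell Toxicity

A few compounds are considered here, and "the series" means these few. Any claim that something is new, unique, unknown or untested is made for them only; others in the source may bear on it.

Measured compounds:
compound 1 `CCC1(Cc2ccccc2)OS(=O)(=O)C=C1OCC#N` — > 400000 nM
compound 2 `CC1(C(c2ccccc2)c2ccccc2)OS(=O)(=O)C=C1OCc1ccccc1` — >= 400000 nM

In an ADME assay on HEL cells (Homo sapiens) for cytotoxicity, with a stated time of 3 days (on this read-out higher numbers stand for lower toxicity in this test and lower numbers for higher toxicity in this test), compound 1 reaches only a limit of the assay, > 400000 nM (the limit of > 400000 nM in this assay, at which 1 of the 2 values shown sits), not a measured number. Compound 2 also stands at a limit in this assay (the limit of >= 400000 nM in this assay, at which 1 of the 2 values shown sits). Going by the values given here, because both results are limits, no step between measured compounds can be sized here, and compound 1 cannot be placed above or below compound 2.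

Compound 3 `CCC1(Cc2ccccc2)OS(=O)(=O)C=C1OC` differs from compound 1 by hydrogen in place of cyano on a saturated chain carbon bound to an oxygen on an unsaturated carbon. Among the compounds with values here, nothing among the measured compounds shows how this change acts in this assay. Given that compound 1 already sits at the limit > 400000 nM, I expect no step beyond the scatter, so the expected step in this assay is a number no higher from compound 1 to compound 3 (the limit leaves the size open). Compound 3 is therefore estimated at 400000 nM, with a range from 200000 nM to 800000 nM, most likely reported again as a limit.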

Compound 3, minimum cytotoxic concentration: > 400000 nM
Compound 3 was reported as a limit (the forecaster's own chance of this, stated with the estimate: 85%); the middle value sits exactly at the limit.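

Compound 1 and compound 3 both end at a limit of this assay rather than at a measured number, so no step between them can be read: the limit of > 400000 nM in this assay, at which 2 of the 3 values shown sit.

The compounds shown leave open whether hydrogen in place of cyano changes cell toxicity at all.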